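The source may hold more compounds than are shown below. What is called first, only, known or untested is meant among the compounds shown, and "the series" means these compounds.

Compound 1 `N=C(N)c1ccc2oc(-c3cccc(OCCCCCOc4ccccc4)c3)cc2c1` and compound 2 `CC(C)NC(=N)c1ccc2oc(-c3cccc(OCCCCCOc4ccccc4)c3)cc2c1` share one core, while compound 3 `N=C(N)c1ccc2cc(-c3cccc(OCCCOc4ccccc4)c3)oc2c1` and the unmeasured compound 4 `CC(C)NC(=N)c1ccc2cc(-c3cccc(OCCCOc4ccccc4)c3)oc2c1` share another; the difference between the two cores is not broken down here. In an ADME assay on L6 cells (Rattus norvegicus) for cytotoxicity, read by resazurin assay, with a stated time of 70 h (on this read-out lower numbers stand for stronger inhibition and higher numbers for weaker inhibition), compound 1 gives 3000 nM, and compound 2 gives 10100 nM. The change between them is isopropyl in place of hydrogen on an amine nitrogen, and this change produced a 3.4-fold higher number from compound 1 to compound 2 (0.53 log units; beyond the scatter). On the other core, compound 3 gives 19800 nM, the highest of the three numbers, though the gap between compound 3 and compound 2 lies within the scatter of such measurements.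

Compound 4 carries the same change relative to compound 3, namely (isopropyl in place of hydrogen on an amine nitrogen). Because the earlier instance of this change gave a 3.4-fold higher number from compound 1 to compound 2 (0.53 log units; beyond the scatter), a step of similar size is expected here, so compound 4 is estimated to give a 3.0-fold higher number from compound 3 to compound 4 (0.48 log units; beyond the scatter) in this assay. Compound 4 is therefore expected to show about 60000 nM, most likely between 22000 nM and 160000 nM, with some chance that this assay returns only a limit rather than a number.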

Compound 4, half-maximal inhibitory concentration: 82300 nM
Estimate against measurement, compound 4: 1.4-fold (0.14 log units) below; low and high end bracket the measured number.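

In this assay, isopropyl in place of hydrogen on an amine nitrogen gives a 4.2-fold higher number from compound 3 to compound 4 (0.62 log units; beyond the scatter), so the change again moves the number upward, towards weaker inhibition. Set beside the earlier case, the change carries over from one core to the other at much the same size: the same change on two cores in this assay, a 3.4-fold higher number (0.53 log units; beyond the scatter) from compound 1 to compound 2 and a 4.2-fold higher number (0.62 log units; beyond the scatter) from compound 3 to compound 4, 1.2-fold (0.09 log units) apart, within the scatter of two such steps. This rests on two pairs alone, so it shows that the step held on these two cores, but not that it would hold on any other core, and it does not explain why the number moves.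

The compounds shown leave open whether another group on that nitrogen, such as methyl, a cyclopentyl ring or a longer chain, would give a step of like size. Among these compounds, they also leave open what the core alone contributes to the number, as no pair here differs only in the core.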